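The source may hold more compounds than are shown below. What is called first, only, known or untested is meant among the compounds shown, and "the series" means these compounds.

In a functional assay on cells (Platelet, Homo sapiens) for inhibition (a lower number here means a stronger inhibitor, a higher number a weaker inhibitor), compound 1 `CCOC(=O)c1ccc(-c2nn(Cc3ccccc3F)c3ccccc23)cc1` gives > 10000 nM, which is a limit of the assay and not a number. Compound 2 `CCOC(=O)c1ccc(-c2nn(Cc3cccc(F)c3)c3ccccc23)cc1` gives in this assay > 10000 nM, again only a limit. Compound 3 `CCOC(=O)c1ccc(-c2nn(C(C)C)c3ccccc23)cc1` gives in this assay > 10000 nM, also a limit. All three values sit at the limit of > 10000 nM in this assay, at which 3 of the 3 values shown sit, so the step that the two limits leave unreadable from compound 1 to compound 2 cannot be read from its two ends, and the same holds for a step that the two limits leave unreadable from compound 1 to compound 3 and for a step that the two limits leave unreadable from compound 2 to compound 3.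

Compound 4 `CCCCn1nc(-c2ccc(C(=O)OCC)cc2)c2ccccc21` differs from compound 1 in one place: propyl in place of 2-fluorophenyl on a saturated chain carbon bound to an aromatic nitrogen. Of the measured steps, a step that the two limits leave unreadable from compound 1 to compound 3 comes nearest, since it too replaces 2-fluorobenzyl on an aromatic nitrogen, there with isopropyl, yet it leaves the size of the change open. None of the three compounds shows any group on that nitrogen bringing the inhibition into the readable range of this assay, so the step that the limit leaves unreadable from compound 1 to compound 4 is expected to stay within the scatter rather than point in either direction. Compound 4 is therefore estimated at 20000 nM, within 5000 nM to 100000 nM, and is most likely to be reported as a limit once more.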

Compound 4, half-maximal inhibitory concentration: > 10000 nM
Compound 4: only a limit was reported; the forecaster's own chance of this, stated with the estimate: 85%; the middle value lies beyond the limit too.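

In this assay compound 4 gives > 10000 nM and this is again only a limit, not a number. Within the data shown here, no step to compound 4 from compound 1, compound 2 or compound 3 can be read, as all four stand at the same limit: the limit of > 10000 nM in this assay, at which 4 of the 4 values shown sit.

The compounds shown leave open whether any group on the aromatic nitrogen brings inhibition into the readable range, and how far these groups differ.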